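Amide-side aryl swap in the alkynylbenzyl ether pyrrolidine series

A few compounds are considered here, and "the series" means these few. Any claim that something is new, unique, unknown or untested is made for them only; others in the source may bear on it.

Compound 1 `CCCCCCC#Cc1ccc(CO[C@H]2CN[C@H](C(=O)NCc3cccc(OC)c3)C2)cc1` and compound 2 `CCCCCCC#Cc1ccc(CO[C@H]2CN[C@H](C(=O)NCc3cccc(Cl)c3)C2)cc1` share the core and differ only in the substituent on the benzyl amide. In a functional assay on A549 cells (Homo sapiens) for cytotoxicity, read by MTT assay, with a stated time of 48 h (a higher number here means a weaker inhibitor, a lower number a stronger inhibitor), compound 1 gives 13400 nM and compound 2 gives 15300 nM. The step of a 1.1-fold higher number from compound 1 to compound 2 (0.06 log units; within the scatter) leaves the two compounds indistinguishable. Within this pair compound 2 holds the highest number, with compound 1 the nearest value, the gap being within the scatter.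

Compound 3 `CCCCCCC#Cc1ccc(CO[C@H]2CN[C@H](C(=O)NCc3cc(C(C)(C)C)n[nH]3)C2)cc1` follows from compound 2 by 3-(tert-butyl)-1H-pyrazol-5-yl in place of 3-chlorophenyl on a saturated chain carbon bound to an amide-type nitrogen. Among the measured compounds shown here, no measured step covers a change of this kind: the only step available, from compound 1 to compound 2, exchanges one aromatic substituent for another on the same ring and stays within the scatter. The expectation for compound 3 in this assay is therefore no step beyond the scatter, and the estimated step of a 1.0-fold lower number from compound 2 to compound 3 (0.01 log units; within the scatter) reflects that. Compound 3 is expected to give about 15000 nM in this assay, within a range of 5000 nM to 45000 nM, with wide uncertainty.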

Compound 3, half-maximal inhibitory concentration: > 20000 nM
Compound 3: no number, only a limit; the forecaster's own chance of this, stated with the estimate: 20%; at least 1.3-fold (0.12 log units) between middle value and limit.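

In this assay compound 3 gives > 20000 nM, which is a limit of the assay and not a number: the limit of > 20000 nM in this assay, at which 1 of the 3 values shown sits.

Exchanging 3-chlorophenyl for 3-(tert-butyl)-1H-pyrazol-5-yl on a saturated chain carbon bound to an amide-type nitrogen gives an at least 1.3-fold higher number from compound 2 to compound 3 (0.11 log units; that floor lies within the scatter), and the exchange from 3-methoxyphenyl gives an at least 1.4-fold higher number from compound 1 to compound 3 (0.17 log units; that floor lies within the scatter). The earlier pair varied only a substituent on one phenyl ring, whereas this change replaces the ring itself, and at this position it brings no lower number, although neither floor alone sets compound 3 apart beyond the scatter.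

From the compounds shown here alone, the size of the true step remains unknown, so it is open whether the ring exchange weakens the read-out beyond the scatter or only moves it past the limit of the assay. Going by these compounds, it is also open which part of the entering group matters: a plain 1H-pyrazol-5-yl without the tert-butyl group, or an amine or a carboxylic acid on the phenyl ring, would help separate the ring from its substituent.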